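Working notes: methoxy to hydroxy from compound 3

This account rests on a few compounds, and the source may have more. Where it says the series, first, only, none or still open, it means among the compounds named here.

Values in a functional assay on KB cells (Homo sapiens) for antiproliferative activity, read by sulforhodamine B assay, with a stated time of 3 days; a lower number here means that less compound is needed, a higher number that more compound is needed for the effect:
- compound 1 `CCC1=C(O)c2c(oc(-c3ccc(C)cc3)cc2=O)C(CC)(CC)C1=O`: 39.2 uM
- compound 2 `CCC1=C(O)c2c(oc(-c3ccc(C)c(C)c3)cc2=O)C(CC)(CC)C1=O`: 35.5 uM
- compound 3 `CCC1=C(O)c2c(oc(-c3ccc(OC)c(C)c3C)cc2=O)C(CC)(CC)C1=O`: 5.43 uM

Compound 3 has the lowest number of the three, and its gaps to the other two lie beyond the scatter. The next change leads to compound 4 `CCC1=C(O)c2c(oc(-c3ccc(O)c(C)c3C)cc2=O)C(CC)(CC)C1=O`: hydrogen in place of methyl on an oxygen on an aromatic ring, or methoxy to hydroxy.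

Within the data shown here, no measured step covers this change. Among the measured compounds shown here, the only single-place step, a 1.1-fold lower number from compound 1 to compound 2 (0.04 log units; within the scatter), is methyl in place of hydrogen on an aromatic carbon. It is a different change and stays within the scatter, so it sets no size here. Compound 3 at 5.43 uM sits well under compound 2 at 35.5 uM, but these two differ in more than one place, and that gap cannot be assigned to the methoxy alone. It gives only a weak lean: losing the methyl from the methoxy may give back part of that gap. In this assay, the expected result is a 1.8-fold higher number from compound 3 to compound 4 (0.27 log units; within the scatter), a moderate move to a higher number, held with little confidence. The estimate for compound 4 is 10 uM, with an expected range from 3 uM to 35 uM.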

Compound 4, concentration for half-maximal effect: 6.5 uM
Compound 4: middle estimate off by 1.5-fold (0.19 log units), on the high side; low and high end bracket the measured number.
By their numbers in this assay, from the lowest: compounds 3 and 4 (each within the scatter of the next); then compounds 2 and 1 (each within the scatter of the next).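

In this assay, methoxy to hydroxy on this ring gives a 1.2-fold higher number from compound 3 to compound 4 (0.08 log units; within the scatter), so at this position the methyl on the oxygen can be exchanged for hydrogen without a readable effect on the number. The low number also holds for the free hydroxy form: 4-hydroxy-2,3-dimethylphenyl in place of 3,4-dimethylphenyl gives a 5.5-fold lower number from compound 2 to compound 4 (0.74 log units; beyond the scatter), and the same group in place of 4-methylphenyl gives a 6.0-fold lower number from compound 1 to compound 4 (0.78 log units; beyond the scatter), both modest steps beyond the scatter that show the gain over these simpler aryl groups does not depend on that methyl. No outside evidence bears on this result.

The compounds shown do not separate the contribution of the oxygen substituent from that of the methyl pattern on the aryl group, since both differ together in the two larger steps. As far as these compounds go, it also remains open whether a longer chain on that oxygen, such as ethoxy, or an amine or a carboxylic acid in place of the hydroxy, would stay level with compound 4 at 6.5 uM in this assay.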